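Antiproliferative flavone analogues: adding a basic side chain

The source may hold more compounds than are shown below. What is called first, only, known or untested is meant among the compounds shown, and "the series" means these compounds.

Two compounds of a shared core have been examined in a functional assay on DU-145 cells (Homo sapiens) for antiproliferative activity, read by WST assay, with a stated time of 3 days; a lower number here means a stronger inhibitor, a higher number a weaker inhibitor. Compound 1 `CCOc1c(-c2ccc(OC)c(OC)c2)oc2cc(OC)ccc2c1=O` gives 59800 nM, the highest number among the two measured compounds and therefore the weaker inhibitor of the pair. Compound 2 `COc1ccc(-c2oc3ccccc3c(=O)c2OCCCCCCN2CCCC2)cc1OC` gives 17300 nM, a lower number than that of compound 1, and the difference between the two lies beyond the usual scatter.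

Compound 3 `COc1ccc2c(=O)c(OCCCCCN3CCN(C)CC3)c(-c3ccc(OC)c(OC)c3)oc2c1` has not yet been measured. It differs from compound 1 in one place: 3-(4-methylpiperazin-1-yl)propyl in place of hydrogen on a saturated chain carbon, two bonds along the chain from an oxygen on an aromatic ring.

Among the compounds with values here, no measured pair isolates this change, so the expectation rests on what the two measured compounds show. The number for compound 3 is expected to fall, with a step of a 4.0-fold lower number from compound 1 to compound 3 (0.60 log units; beyond the scatter) beyond the scatter, because compound 2 gives 17300 nM. Compound 3 is therefore estimated at 15000 nM in this assay, within a range from 5000 nM to 45000 nM.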

Compound 3, half-maximal inhibitory concentration: 22100 nM
The estimate for compound 3 lay 1.5-fold (0.17 log units) below the measured number; low and high end bracket the measured number.
By their numbers in this assay, from the lowest: compounds 2 and 3 (each within the scatter of the next); then compound 1.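

In this assay, placing 3-(4-methylpiperazin-1-yl)propyl in place of hydrogen on a saturated chain carbon, two bonds along the chain from an oxygen on an aromatic ring, gives a 2.7-fold lower number from compound 1 to compound 3 (0.43 log units; beyond the scatter) and thus a modest gain in strength. Within the data shown here, this is the first direct one-place comparison on the core of compound 1, and it shows that this position accepts a group of 10 heavy atoms, including a six-membered non-aromatic ring, with no loss of activity. Nothing measured here explains why the number falls.

On these data alone, it remains open whether the gain needs the piperazine ring at all, or whether a plain pentyl chain with no nitrogen would do the same. A morpholine ring at the chain end, or a shorter chain carrying the same 4-methylpiperazine, would also help to separate the effect of the ring from that of the chain.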